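Chloro substitution on the aromatic ring of the oxazoline series

A few compounds are considered here, and "the series" means these few. Any claim that something is new, unique, unknown or untested is made for them only; others in the source may bear on it.

Of the compounds shown here, three have numbers so far. Compound 1 `NC1=N[C@@H](c2ccccc2)CO1` gives 67 nM in a functional assay on HEK293 cells for agonist activity at trace amine-associated receptor 1 (Homo sapiens), read by cAMP accumulation, with a stated time of 30 min; on this read-out lower numbers stand for an effect already at smaller amounts and higher numbers for an effect only at larger amounts of compound. Compound 2 `CCN(C[C@H]1COC(N)=N1)c1ccccc1` gives 59 nM in this assay, and compound 3 `CCN(C[C@H]1COC(N)=N1)c1cccc(Cl)c1` gives 29 nM. How the core of compound 1 differs from that of compound 2 is not broken down here; their two numbers lie within the scatter of each other. Going by the values given here, the single counted step on file is a 2.0-fold lower number from compound 2 to compound 3 (0.31 log units; beyond the scatter), a change described as chloro in place of hydrogen on an aromatic carbon, where the entering group sits meta to a large group.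

Compound 4 `NC1=N[C@@H](c2ccccc2Cl)CO1` has not yet been measured. It differs from compound 1 by chloro in place of hydrogen on an aromatic carbon, the entering group here sitting ortho to a group of 6 heavy atoms. This is the same kind of change as that from compound 2 to compound 3, though on a different core and at a different place on the ring, so the earlier step is a guide rather than a rule; it occurs nowhere else among the compounds shown.

On that single precedent, resting on compound 1 at 67 nM together with the step of a 2.0-fold lower number from compound 2 to compound 3 (0.31 log units; beyond the scatter), the step in this assay is expected to be a 1.7-fold lower number from compound 1 to compound 4 (0.22 log units; within the scatter). Compound 4 is therefore estimated at 40 nM, with a plausible span from 15 nM to 120 nM to allow for the changed place of the chloro.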

Compound 4, half-maximal effective concentration: 23 nM
Compound 4: middle estimate off by 1.7-fold (0.24 log units), on the high side; measured number inside the range.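

In this assay, chloro in place of hydrogen on an aromatic carbon, ortho to a group of 6 heavy atoms, gives a 2.9-fold lower number from compound 1 to compound 4 (0.46 log units; beyond the scatter), so the change lowers the number on the core of compound 1 as it does on the core of compound 2. The two steps point the same way and do not differ beyond what repeated measurements allow: the same change on two cores in this assay, a 2.0-fold lower number (0.31 log units; beyond the scatter) from compound 2 to compound 3 and a 2.9-fold lower number (0.46 log units; beyond the scatter) from compound 1 to compound 4, 1.4-fold (0.16 log units) apart, within the scatter of two such steps. This supports carrying the chloro step between these two cores in this assay, but it rests on one pair of steps in which both the core and the place of the chloro differ, so the contribution of each cannot be separated, and neither a general rule for the series nor a reason for the lower numbers follows from it.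

The compounds shown leave open whether fluoro, bromo, methyl or methoxy entering at the same place on the ring of compound 1 would give a step of similar size, and whether the chloro step holds at other places on that ring. They also leave open whether the chloro step persists on the core of compound 2 when a longer chain replaces the ethyl group on the nitrogen.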